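The source may report more compounds than this note shows. Statements on the series, on what has been measured and on what is new or still open speak of the compounds shown alone.

Working notes on the series. Compound 1 `O=C(/C=C/c1cc(Br)ccc1O)c1ccc(Br)cc1` and compound 2 `Cc1ccc(C(=O)/C=C/c2cc(Br)ccc2O)cc1` share one core; compound 3 `N#CC1=C(N)Oc2ccc(Br)cc2C1CC(=O)c1ccc(Br)cc1` is built on another, and the difference between the two cores is not broken down here. Compound 4 `Cc1ccc(C(=O)CC2C(C#N)=C(N)Oc3ccc(Br)cc32)cc1` has not yet been measured. In an ADME assay on MCF-10A cells (Homo sapiens) for cytotoxicity, read by sulforhodamine B assay, with a stated time of 72 h, tested at 30 uM (on this read-out lower numbers stand for a weaker effect and higher numbers for a stronger effect at the one concentration tested), compound 1 gives 47.6%. In this assay compound 2 gives 49.4%, and compound 3 gives 43.6%; all three numbers sit within the scatter of one another. The change from compound 1 to compound 2 is methyl in place of bromo on an aromatic carbon, and the measured step is a number 1.8 percentage points higher from compound 1 to compound 2 (within the scatter). The same change, (methyl in place of bromo on an aromatic carbon), carries compound 3 into compound 4, at the same place on the ring. Because a number 1.8 percentage points higher from compound 1 to compound 2 (within the scatter) lay within the scatter, the corresponding step is expected to be about as small, a number 1.4 percentage points higher from compound 3 to compound 4 (within the scatter). Compound 4 is therefore estimated at 45%, with a range from 33% to 57%.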

Compound 4, a percentage reported as activity, at one concentration (the size of the read-out at that concentration, not a potency): 33.5%
Beside the measured number, compound 4's estimate is 11.5 percentage points above it; low and high end bracket the measured number.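

In this assay, 4-bromophenyl to 4-methylphenyl on the core of compound 3 gives a number 10.1 percentage points lower from compound 3 to compound 4 (beyond the scatter). Set beside the step on the other core, this does not establish that the two cores respond differently to the change: the same change on two cores in this assay, a number 1.8 percentage points higher (within the scatter) from compound 1 to compound 2 and a number 10.1 percentage points lower (beyond the scatter) from compound 3 to compound 4, 11.9 percentage points apart, within the scatter of two such steps. The opposite directions therefore cannot be read as a dependence on the core, yet with one pair on each core they do not show that the step carries over reliably either.

Open, going by these compounds, is how a methoxy, a chloro or an amine in that same place would read on either core. Also open, on these data alone, is whether the bromo on the other ring of compound 3 and compound 4 contributes to these read-outs.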